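The source may hold more compounds than are shown below. What is called first, only, known or untested is meant among the compounds shown, and "the series" means these compounds.

The study concerns three measured compounds and one that still awaits measurement. Compound 1 `Cc1cc2[nH]nc(N)c2c(=O)[nH]1` and compound 2 `CC(C)(C)c1cc2[nH]nc(N)c2c(=O)[nH]1` share one core, while compound 3 `Cc1cc2nn(-c3ccccc3)c(N)c2c(=O)[nH]1` is built on a different core; the difference between the two cores is not broken down here. In an assay on isolated protein for inhibition of RAC-alpha serine/threonine-protein kinase (Homo sapiens), read by mobility shift assay, tested at 30 uM (on this read-out lower numbers stand for less inhibition and higher numbers for more inhibition at the one concentration tested (going by the name of the read-out)), compound 1 gives -3%, compound 2 gives 3% and compound 3 gives 5%, and all three numbers lie within the usual scatter of one another, so no order among them can be read. The change from compound 1 to compound 2 is tert-butyl in place of methyl on an aromatic carbon, and it made a number 6 percentage points higher from compound 1 to compound 2 (within the scatter). Compound 4 `CC(C)(C)c1cc2nn(-c3ccccc3)c(N)c2c(=O)[nH]1` arises from compound 3 by the same change, (tert-butyl in place of methyl on an aromatic carbon), at a place described in identical terms. Because the earlier step of a number 6 percentage points higher from compound 1 to compound 2 (within the scatter) stayed within the scatter, the step expected here is likewise small, a number 1 percentage points higher from compound 3 to compound 4 (within the scatter). Compound 4 is therefore estimated to give 6% in this assay, with a likely range from -6% to 18%.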

Compound 4, a percentage reported as inhibition, at one concentration (the size of the read-out at that concentration, not a potency): 7%
Compound 4: the middle estimate sits 1 percentage points below what was measured; the measured number falls inside the stated range.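

In this assay, tert-butyl in place of methyl on an aromatic carbon again left only a small step on the second core, with a number 2 percentage points higher from compound 3 to compound 4 (within the scatter). Set beside the earlier step, the change looks alike on the two cores as far as this read-out can tell: the same change on two cores in this assay, a number 6 percentage points higher (within the scatter) from compound 1 to compound 2 and a number 2 percentage points higher (within the scatter) from compound 3 to compound 4, 4 percentage points apart, within the scatter of two such steps. This agreement is weak evidence for transfer, however, as both steps stay within the scatter and a change with no effect on either core would give the same picture, so it does not show how the change would carry over to a compound with clear inhibition.

The compounds shown leave open whether a different group at this aromatic carbon, such as an amine, a carboxylic acid or a longer chain, would give a step beyond the scatter. They also leave open whether the small step seen with tert-butyl would hold on a core that gives substantial inhibition at the concentration tested.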